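The compounds below may be only part of what the source reports. "The series", "measured", "known", "first", "only" and "open" are said of these compounds alone.

Measured so far in an assay on isolated protein for inhibition of NAD-dependent protein deacylase sirtuin-6 (Homo sapiens), read by fluorescence, tested at 200 uM; a lower number here means less inhibition, a higher number more inhibition at the concentration tested (going by the name of the read-out):
compound 1, `O=C(Nc1ccc(O)c(C(=O)O)c1)c1ccc(N2C(=O)CCS2(=O)=O)cc1`, gives 89%
compound 2, `O=C(Nc1ccc(O)c(C(=O)O)c1)c1ccc(NC(=O)c2ccco2)cc1`, gives 100%
compound 3, `O=C(Nc1ccc(C(=O)O)c(O)c1)c1cccc(N2C(=O)CCS2(=O)=O)c1`, gives 44%

Compound 2 differs from compound 1 by a group of 8 heavy atoms (5 carbon, 1 nitrogen, 2 oxygen; one five-membered aromatic ring with 1 hetero atom) in place of a group of 8 heavy atoms (3 carbon, 1 nitrogen, 3 oxygen, 1 sulfur; one five-membered non-aromatic ring with 2 hetero atoms), on an aromatic carbon. In this assay that exchange gives a number 11 percentage points higher from compound 1 to compound 2 (beyond the scatter). Compound 4, `O=C(Nc1ccc(C(=O)O)c(O)c1)c1cccc(NC(=O)c2ccco2)c1`, stands to compound 3 as compound 2 stands to compound 1: a group of 8 heavy atoms (5 carbon, 1 nitrogen, 2 oxygen; one five-membered aromatic ring with 1 hetero atom) in place of a group of 8 heavy atoms (3 carbon, 1 nitrogen, 3 oxygen, 1 sulfur; one five-membered non-aromatic ring with 2 hetero atoms), on an aromatic carbon. The two changes are of the same kind, not the same: in compound 1 the exchanged group sits para to a large group, in compound 3 meta to a large group. How the core of compound 3 differs from the core of compound 1 is not broken down here; the two readings show compound 3 well below compound 1. Compound 4 has not yet been measured.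

For the measured compounds named here, the expectation rests on the one measured step, read with the reservation that compound 1 already sits high at 89% and leaves little room upward, whereas compound 3 starts much lower. A step for compound 4 at least as large as the one already seen is therefore expected, a number 16 percentage points higher from compound 3 to compound 4 (beyond the scatter). The estimate for compound 4 is 60%, expected to fall between 40% and 85%.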

Compound 4, a percentage reported as inhibition, at one concentration (the size of the read-out at that concentration, not a potency): 62%
Beside the measured number, compound 4's estimate is 2 percentage points below it; low and high end bracket the measured number.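

In this assay the ((furan-2-yl)carbonyl)amino group in place of the five-membered non-aromatic ring gives a number 18 percentage points higher from compound 3 to compound 4 (beyond the scatter), and the earlier step on the other core can now be set beside it: the same change on two cores in this assay, a number 11 percentage points higher (beyond the scatter) from compound 1 to compound 2 and a number 18 percentage points higher (beyond the scatter) from compound 3 to compound 4, 7 percentage points apart, within the scatter of two such steps. Across these two pairs, the change therefore carries from one core to the other in the same direction, with no measurable difference in step size between the cores. This does not establish a general rule for the series: it rests on two pairs read at a single concentration, with no potency, and compound 2 gives 100%, so the step on the core of compound 1 may not show the full size of the change.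

Going by these compounds, whether a plain amine or a thiophene-carbonyl amino group at the same place would give a similar step remains open. The compounds shown also leave open whether the step depends on the furan ring or on the amide linking it to the core.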